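Swapping the acyl ring on the compound 3 amide

A few compounds are considered here, and "the series" means these few. Any claim that something is new, unique, unknown or untested is made for them only; others in the source may bear on it.

Measured in a physicochemical assay for solubility, read by LC-MS, in phosphate buffer, with a stated time of 24 h, at pH 6.8; a lower number here means a less soluble compound, a higher number a more soluble compound:
Compound 1 `C[C@@H](c1ccc(NC(=O)N2CC(c3cncc(N)c3)C2)cc1)N1Cc2ccccc2C1=O`: 35000 nM
Compound 2 `C[C@H](NC(=O)c1cccc(F)c1)c1ccc(NC(=O)N2CC(c3cncc(N)c3)C2)cc1`: 17000 nM
Compound 3 `C[C@H](NC(=O)C1CCOCC1)c1ccc(NC(=O)N2CC(c3cncc(N)c3)C2)cc1`: 440000 nM

Compound 3 stands highest of the three at 440000 nM, and both steps up to it lie beyond the scatter: a 13-fold higher number from compound 1 to compound 3 (1.10 log units; beyond the scatter) and a 26-fold higher number from compound 2 to compound 3 (1.41 log units; beyond the scatter). The next structure is compound 4 `C[C@H](NC(=O)[C@@H]1CCCN1C)c1ccc(NC(=O)N2CC(c3cncc(N)c3)C2)cc1`, reached through (1-methylpyrrolidin-2-yl in place of oxan-4-yl on a carbonyl carbon), that is, 1-methylpyrrolidin-2-yl in place of oxan-4-yl on a carbonyl carbon.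

The closest measured precedent is a 26-fold higher number from compound 2 to compound 3 (1.41 log units; beyond the scatter), a large step at the same carbonyl carbon, but it started from 3-fluorophenyl. The other steps, a 2.1-fold lower number from compound 1 to compound 2 (0.31 log units; beyond the scatter) (modest) and a 13-fold higher number from compound 1 to compound 3 (1.10 log units; beyond the scatter) (large), change a larger group. For the measured compounds named here, no measured step exchanges one non-aromatic ring for another, so these sizes carry over poorly, and the range stays wide. The estimated step in this assay is a 1.1-fold higher number from compound 3 to compound 4 (0.06 log units; within the scatter), so no change beyond the scatter is expected. For compound 4 the estimated value is 500000 nM, with an expected range of 150000 nM to 1500000 nM.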

Compound 4, solubility: 820000 nM
Compound 4: middle estimate off by 1.6-fold (0.21 log units), on the low side; measured number inside the range.
By their numbers in this assay, from the lowest: compound 2; then compound 1; then compounds 3 and 4 (each within the scatter of the next).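

In this assay, for the compounds shown here, the first exchange of one non-aromatic ring for another on this carbonyl carbon gives a 1.9-fold higher number from compound 3 to compound 4 (0.27 log units; within the scatter) and so leaves compound 3 and compound 4 without an order. The two non-aromatic ring amides therefore stand together against the other two compounds, with a 48-fold higher number from compound 2 to compound 4 (1.68 log units; beyond the scatter) matching the large gain already seen in a 26-fold higher number from compound 2 to compound 3 (1.41 log units; beyond the scatter) and a 23-fold higher number from compound 1 to compound 4 (1.37 log units; beyond the scatter) matching the one seen in a 13-fold higher number from compound 1 to compound 3 (1.10 log units; beyond the scatter) at the wider change of group. No available measurement accounts for these numbers.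

Ring size and the exchange of ring oxygen for ring nitrogen change together in the step between compound 3 and compound 4, so the two remain unseparated. Open, on these data alone, is how 1-methylpiperidin-4-yl, which keeps the six-membered ring and carries a nitrogen, or pyrrolidin-2-yl without the methyl would read in this assay on this carbonyl carbon.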